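Removing the piperazine from two heteroaryl-linked analogues

The compounds below may be only part of what the source reports. "The series", "measured", "known", "first", "only" and "open" are said of these compounds alone.

The measured compounds:
Compound 1 `Cc1ccc(-n2cc(-c3ccc(CN4CCN(C)CC4)c(C(F)(F)F)c3)nn2)cc1Nc1nccc(-c2cccnc2)n1` gives 40 nM in a functional assay on K562 cells (Homo sapiens) for inhibition, read by MTT assay, with a stated time of 72 h; a lower number here means a stronger inhibitor, a higher number a weaker inhibitor.
Compound 2 `Cc1ccc(-n2cc(-c3ccc(C)c(C(F)(F)F)c3)nn2)cc1Nc1nccc(-c2cccnc2)n1` gives > 30000 nM, which is a limit of this assay and not a number (the limit of > 30000 nM in this assay, at which 1 of the 3 values shown sits).
Compound 3 `Cc1ccc(-c2nnc(-c3ccc(CN4CCN(C)CC4)c(C(F)(F)F)c3)o2)cc1Nc1nccc(-c2cccnc2)n1` gives 510 nM in this assay.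

Compound 1 and compound 3 carry different cores, and the difference between the two cores is not broken down here. On the core of compound 1, the change hydrogen in place of 4-methylpiperazin-1-yl on a saturated chain carbon bound to an aromatic carbon produced an at least 750-fold higher number from compound 1 to compound 2 (2.87 log units; beyond the scatter).

Compound 4 `Cc1ccc(-c2nnc(-c3ccc(C)c(C(F)(F)F)c3)o2)cc1Nc1nccc(-c2cccnc2)n1` is not yet measured. Among the measured compounds shown here, it is related to compound 3 by hydrogen in place of 4-methylpiperazin-1-yl on a saturated chain carbon bound to an aromatic carbon, the same change, made at the same place, as the one that turned compound 1 into compound 2. Since compound 3 already stands weaker than compound 1, the outcome is expected to lie at or beyond the limit. The step from compound 3 to compound 4 is expected to be a 78-fold higher number from compound 3 to compound 4 (1.89 log units; beyond the scatter), because the same change gave an at least 750-fold higher number from compound 1 to compound 2 (2.87 log units; beyond the scatter). Compound 4 is therefore expected to give about 40000 nM in this assay, with a likely range from 8000 nM to 200000 nM.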

Compound 4, half-maximal inhibitory concentration: > 30000 nM
Compound 4: a limit, no number; the forecaster's own chance of this, stated with the estimate: 75%; the middle value is on the limit's open side.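

In this assay compound 4 gives > 30000 nM, which is a limit of the assay and not a number: the limit of > 30000 nM in this assay, at which 2 of the 4 values shown sit.

Taking away the 4-methylpiperazin-1-yl group gives an at least 58-fold higher number from compound 3 to compound 4 (1.76 log units; beyond the scatter), so on this second core too the change costs a large part of the activity, and its direction carries over from one core to the other in these two pairs. What this does not show is whether the change costs the same amount on both cores, since each step has only a lower bound: the same change on two cores in this assay, an at least 750-fold higher number (2.87 log units; beyond the scatter) from compound 1 to compound 2 and an at least 58-fold higher number (1.76 log units; beyond the scatter) from compound 3 to compound 4; the limit leaves it open whether they differ.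

The compounds shown leave open how large either step really is, and whether a dimethylamino group or a morpholine ring on the same saturated chain carbon would keep the activity seen with the 4-methylpiperazin-1-yl group. With compound 2 and compound 4 both at the limit, the two cores also cannot be compared once that group is gone.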